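A few compounds are considered here, and "the series" means these few. Any claim that something is new, unique, unknown or untested is made for them only; others in the source may bear on it.

Working notes on the series. Compound 1 `COc1ccc(SCc2ccc(/C=C/C(=O)Nc3ccccc3N)cc2)cc1OC` is the reference here: in a functional assay on HCT-116 cells (Homo sapiens) for inhibition, read by CCK-8 assay, with a stated time of 72 h, tested at 2 uM (on this read-out higher numbers stand for more inhibition of growth at the one concentration tested and lower numbers for less inhibition of growth), compound 1 gives 12.9%, the highest of the three numbers recorded. Compound 3 `Nc1ccccc1NC(=O)c1ccc(CSc2cccc(F)c2)cc1` gives 5.5% in this assay, which lies within the scatter of compound 1. Compound 2 `Nc1ccccc1NC(=O)c1ccc(CSc2ccc(C(F)(F)F)cn2)cc1` gives 1.2% in this assay, a number beyond the scatter below compound 1. Going by the values given here, no two measured compounds differ in one place, so no single-point step is available to calibrate the next change. Compound 4 `CCc1ccc(SCc2ccc(/C=C/C(=O)Nc3ccccc3N)cc2)cc1` carries 4-ethylphenyl in place of 3,4-dimethoxyphenyl on a sulfur. Among the compounds with values here, with no matching step to lean on, the expected change in this assay is a number 2.9 percentage points lower from compound 1 to compound 4 (within the scatter), that is none beyond the scatter, leaning slightly downward. Compound 4 is thus estimated at 10%, within 0% to 24%.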

Compound 4, percent growth inhibition at one concentration: 3.29%
Compound 4: middle estimate off by 6.7 percentage points, on the high side; low and high end bracket the measured number.
By their numbers in this assay, from the lowest: compounds 2, 4, 3 and 1 (each within the scatter of the next, the first and the last beyond it).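

Going by these compounds alone, the first single-point step at this position, 4-ethylphenyl in place of 3,4-dimethoxyphenyl on a sulfur, gives in this assay a number 9.6 percentage points lower from compound 1 to compound 4 (within the scatter) and so resolves no difference between these two groups. Exchanging this aryl group on the shared core therefore shifts the number by no more than repeated measurements would. Nothing measured here bears on the reason for the size of this step.

Open, from the compounds shown here alone, is whether a carboxylic acid or an amine on this aryl group, or a longer chain in place of ethyl, would move the number beyond the scatter. Also open, going by these compounds, is whether the same exchange behaves alike on the core of compound 3.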